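Moving the chlorine around the pendant ring

A few compounds are considered here, and "the series" means these few. Any claim that something is new, unique, unknown or untested is made for them only; others in the source may bear on it.

Compound 2 `Cn1c(-c2ccc(Cl)cc2)nc2c(NC3CCCC3)ncnc21` carries a 4-chlorophenyl group on the shared core, and in an assay on CHO cells for displacement of a labelled ligand from adenosine receptor A1 (Homo sapiens), read by scintillation counting, with a stated time of 3 h (a lower number here means a stronger inhibitor, a higher number a weaker inhibitor), compound 2 gives 18 nM. Among the two numbers measured so far this is the higher one, though the gap is small: compound 1 `Cn1c(-c2ccc(O)cc2)nc2c(NC3CCCC3)ncnc21`, which bears a hydroxy group instead of the chlorine, gives in this assay a value of 17 nM, and the step of a 1.1-fold higher number from compound 1 to compound 2 (0.02 log units; within the scatter) lies within the scatter. Compound 3 `Cn1c(-c2ccccc2Cl)nc2c(NC3CCCC3)ncnc21` is built from the same atoms as compound 2, joined differently. The change is 2-chlorophenyl in place of 4-chlorophenyl on an aromatic carbon. Among the measured compounds shown here, the only measured step swaps one group for another at the same attachment point; it says nothing about shifting the chlorine to a different carbon of that ring, so no measured step bears directly on this change. The expected step is a 2.2-fold higher number from compound 2 to compound 3 (0.35 log units; beyond the scatter), a modest weakening with wide uncertainty. Compound 3 is therefore estimated at 40 nM, with a range from 10 nM to 200 nM.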

Compound 3, inhibition constant: 37 nM
Compound 3: the middle estimate sits 1.1-fold (0.03 log units) above what was measured; measured number inside the range.
By their numbers in this assay, from the lowest: compounds 1 and 2 (each within the scatter of the next); then compound 3.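

Moving the chlorine registers in this assay where the earlier swap did not: 2-chlorophenyl in place of 4-chlorophenyl gives a 2.1-fold higher number from compound 2 to compound 3 (0.31 log units; beyond the scatter) as a modest step beyond the scatter. The comparison with the hydroxy compound gives a similar picture, with a 2.2-fold higher number from compound 1 to compound 3 (0.34 log units; beyond the scatter) also modest and beyond the scatter. So for these compounds, where the chlorine sits on the pendant ring changes the number more than replacing hydroxy with chlorine did, and nothing available explains why the number rises.

These compounds leave open whether a hydroxy group moved in the same way would follow the chlorine. They also do not show how an amine or a carboxylic acid on the pendant ring, or a longer chain in place of that ring, would behave in this assay.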